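Swapping the Group on the Sulfonyl Ring of a Quinazoline

The source may hold more compounds than are shown below. What is called first, only, known or untested is meant among the compounds shown, and "the series" means these compounds.

Measured so far:
compound 1 `COc1cc2nc(N3CCN(S(=O)(=O)c4cccc([N+](=O)[O-])c4)CC3)nc(N)c2cc1OC` gives 32000 nM
compound 2 `COc1cc2nc(N3CCN(S(=O)(=O)c4ccc(OC(F)(F)F)cc4)CC3)nc(N)c2cc1OC` gives 25000 nM

Going by the values given here, in a functional assay on PC-3 cells (Homo sapiens) for inhibition (on this read-out lower numbers stand for stronger inhibition and higher numbers for weaker inhibition), compound 2 has the lowest of the two numbers, yet its only neighbour, compound 1, sits within the usual scatter: a 1.3-fold lower number from compound 1 to compound 2 (0.11 log units; within the scatter). The two compounds therefore cannot be ranked.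

Compound 3 `COc1cc2nc(N3CCN(S(=O)(=O)c4ccc(S(C)(=O)=O)cc4)CC3)nc(N)c2cc1OC` has not been measured. It differs from compound 2 in one place: methylsulfonyl in place of trifluoromethoxy on an aromatic carbon. Among the compounds with values here, the only measured step, from compound 1 to compound 2, also exchanged the group on the phenyl ring attached to the sulfonyl sulfur, and it stayed within the scatter. On that single precedent, another exchange at the same position is expected to give no step beyond the scatter in this assay. The expected step is a 1.1-fold higher number from compound 2 to compound 3 (0.05 log units; within the scatter).

Compound 3 is therefore estimated at 28000 nM, with a range from 10000 nM to 80000 nM.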

Compound 3, half-maximal inhibitory concentration: 17000 nM
Compound 3: middle estimate off by 1.6-fold (0.22 log units), on the high side; the measured number falls inside the stated range.
By their numbers in this assay, from the lowest: compounds 3, 2 and 1 (each within the scatter of the next).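

In this assay, methylsulfonyl in place of trifluoromethoxy gives a 1.5-fold lower number from compound 2 to compound 3 (0.17 log units; within the scatter) and 4-(methylsulfonyl)phenyl in place of 3-nitrophenyl gives a 1.9-fold lower number from compound 1 to compound 3 (0.27 log units; within the scatter). With three different groups now compared on the ring attached to the sulfonyl sulfur, every step between them stays within the scatter, so compounds 1, 2 and 3 cannot be ranked, and this holds across the three groups shown, not just one pair. No other evidence bears on what these numbers mean.

On these data alone, it remains open whether an amine or a carboxylic acid on this ring would give a step beyond the scatter. The compounds shown also leave open whether a longer chain there, or a change away from this ring, would separate itself from these three.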